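The source may hold more compounds than are shown below. What is called first, only, known or untested is meant among the compounds shown, and "the series" means these compounds.

Compound 2 `COc1ccc2[nH]c(=O)c(-c3nc4ccccc4[nH]3)cc2c1` is the starting point. In a functional assay on BEL-7404 cells for cytotoxicity against BEL-7404 tumor cell line (Homo sapiens), read by MTT assay, with a stated time of 48 h (a lower number here means a stronger inhibitor, a higher number a weaker inhibitor), compound 2 gives > 100000 nM, which is a limit of the assay and not a number. Compound 1 `Cc1ccc2[nH]c(=O)c(-c3nc4ccccc4[nH]3)cc2c1` stands at the same place: in this assay compound 1 gives > 100000 nM, again only a limit. Because of the limit of > 100000 nM in this assay, at which 2 of the 3 values shown sit, the step that the two limits leave unreadable from compound 1 to compound 2 cannot be read. Among the compounds with values here, compound 3 `O=c1[nH]c2ccccc2cc1-c1nc2cc(F)ccc2[nH]1`, which also carries a halogen, is the one compound with a measurable value; in this assay compound 3 gives 27500 nM. Within the data shown here, no step is written between compound 3 and either of the other two, so only the values can be set side by side. Compound 4 `COc1ccc2[nH]c(=O)c(-c3nc4cc(Br)ccc4[nH]3)cc2c1` differs from compound 2 by bromo in place of hydrogen on an aromatic carbon. No measured step mirrors this change, and the only step shown is unreadable, so the measurable value of halogen-bearing compound 3 is the nearest hint. The step of an at least 1.6-fold lower number from compound 2 to compound 4 (0.22 log units; that floor lies within the scatter) is therefore expected to be small and toward stronger inhibition, and may well stay within the scatter. Compound 4 is estimated at 60000 nM, within 15000 nM to 200000 nM.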

Compound 4, half-maximal inhibitory concentration: > 100000 nM
Compound 4: only a limit was reported; the forecaster's own chance of this, stated with the estimate: 40%; at least 1.6-fold (0.22 log units) between middle value and limit.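

No step can be read from compound 2 to compound 4, because both stand only at a limit: the limit of > 100000 nM in this assay, at which 3 of the 4 values shown sit. The compounds shown leave open how large any effect of bromo in place of hydrogen on an aromatic carbon is in this assay.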